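The source may hold more compounds than are shown below. What is called first, only, known or untested is meant among the compounds shown, and "the series" means these compounds.

Measured in an ADME assay on S9 fraction from liver (Rattus norvegicus) for metabolic stability, read by LC-MS, using NADPH, with a stated time of 30 min; on this read-out higher numbers stand for a more stable compound and lower numbers for a less stable compound:
- compound 1 `CCCCCCCCc1ccc(OCC(=O)Cn2nnc(-c3cccc(Cl)c3)n2)cc1`: 69%
- compound 2 `CCCCCCCCc1ccc(OCC(=O)Cn2nnc(C(=O)OC)n2)cc1`: < 5%

On these data alone, the reading for compound 2 is a limit of the assay and not a number, so its exact place is unknown. In this small set, (the limit of < 5% in this assay, at which 1 of the 2 values shown sits).

For the measured compounds named here, the only measured step at this place on the molecule is a number at least 64 percentage points lower from compound 1 to compound 2 (beyond the scatter), with methoxycarbonyl in place of 3-chlorophenyl on an aromatic carbon. That step shows that the group here can shift the read-out a long way. Compound 3 `CCCCCCCCc1ccc(OCC(=O)Cn2nnc(CCC(=O)O)n2)cc1` gives up the same methoxycarbonyl: 2-carboxyethyl in place of methoxycarbonyl on an aromatic carbon. In words, this is 2-carboxyethyl in place of methoxycarbonyl. Going by the values given here, no measured compound carries 2-carboxyethyl, so the size of any change is uncertain. Still, with a number at least 64 percentage points lower from compound 1 to compound 2 (beyond the scatter) as the guide, a clear rise in this assay is expected, beyond the scatter.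

The expected change is a number at least 40 percentage points higher from compound 2 to compound 3 (beyond the scatter).

For compound 3 the estimate is 45%, with an expected range of 15% to 80%.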

Compound 3, percent of the compound remaining: < 5%
Compound 3: a limit, no number (the forecaster's own chance of this, stated with the estimate: 10%); middle value at least 40 percentage points from the limit.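

A second group now stands against the 3-chlorophenyl of compound 1: in this assay, 2-carboxyethyl in its place gives a number at least 64 percentage points lower from compound 1 to compound 3 (beyond the scatter), so the large drop at this position is not tied to methoxycarbonyl alone. Compound 2 and compound 3 both sit at a limit of the assay, and the step between them cannot be read: the limit of < 5% in this assay, at which 2 of the 3 values shown sit. Of the three groups shown on this aromatic carbon, only the 3-chlorophenyl keeps the read-out off that limit, and it is also the only one of the three that carries a ring.

On these data alone, whether a plain phenyl without the chlorine, or a ring-free hexyl chain, would also stay off the limit remains open. So does how far apart compound 2 and compound 3 really lie.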